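Propyl on the benzyl ring of the chlorophenyl acid

The source may hold more compounds than are shown below. What is called first, only, known or untested is meant among the compounds shown, and "the series" means these compounds.

Series read-out: an assay on Midbrain with Type-2 angiotensin II receptor (Rattus norvegicus) as the target; on this read-out lower numbers stand for stronger inhibition and higher numbers for weaker inhibition. Three compounds are measured. Compound 1 `CCc1nc2c(C)cc(C)nc2n1Cc1ccc(OC(C(=O)O)c2ccccc2C)cc1` gives 5200 nM. Compound 2 `CCc1nc2c(C)cc(C)nc2n1Cc1ccc(OC(C(=O)O)c2ccccc2Cl)cc1` gives 15000 nM. Compound 3 `CCc1nc2c(C)cc(C)nc2n1Cc1ccc(OC(C(=O)O)c2ccccc2)c(C(C)C)c1` gives 3300 nM. Compound 2 stands at the highest of the three numbers; compound 1 is nearest to it and compound 3 furthest, both with lower numbers.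

Going by the values given here, the one single-point step available is a 2.9-fold higher number from compound 1 to compound 2 (0.46 log units; beyond the scatter), a chloro in place of methyl on an aromatic carbon. It does not touch the place changed here, so it bears only indirectly, as a gauge of how far a small aromatic substitution moves this assay.

Compound 4 `CCCc1cc(Cn2c(CC)nc3c(C)cc(C)nc32)ccc1OC(C(=O)O)c1ccccc1Cl` differs from compound 2 by propyl in place of hydrogen on an aromatic carbon, ortho to a large group and meta to a large group. Among the compounds with values here, no measured pair isolates an alkyl at this place; compound 3 carries an isopropyl on the same ring but also differs elsewhere, so its comparison with compound 1 and compound 2 shows only that the compound with the alkyl-bearing benzyl ring has the lowest of the three numbers.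

Expectation for compound 4: a modest lowering of the number relative to compound 2, within a 1.9-fold lower number from compound 2 to compound 4 (0.27 log units; within the scatter), is estimated, with wide uncertainty. The estimate for compound 4 in this assay is 8000 nM, expected between 2500 nM and 25000 nM.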

Compound 4, half-maximal inhibitory concentration: > 1000 nM
Compound 4 gave a limit, no number; the forecaster's own chance of this, stated with the estimate: 10%; the middle value does not contradict the limit.
By their numbers in this assay, from the lowest: compounds 3 and 1 (each within the scatter of the next); then compound 2.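

In this assay compound 4 gives > 1000 nM, which is a limit and not a number. Going by these compounds alone, no step from compound 2 to compound 4 can be read from it. The compounds shown leave open whether propyl in place of hydrogen on this aromatic carbon lowers, raises or leaves unchanged the number in this assay.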